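Mirror-Image Pair in the Cytosolic Glucosaminidase Series

A few compounds are considered here, and "the series" means these few. Any claim that something is new, unique, unknown or untested is made for them only; others in the source may bear on it.

Measured so far:
compound 1, `O=C(O)[C@@H]1NCC=C[C@@H]1O`: 14%
compound 2, `O=C(O)[C@H]1NC[C@H](O)[C@H](O)[C@@H]1O`: 26%

In an assay on isolated protein for inhibition of cytosolic endo-beta-N-acetylglucosaminidase (Homo sapiens), tested at 1000 uM (on this read-out lower numbers stand for less inhibition and higher numbers for more inhibition at the one concentration tested (going by the name of the read-out)), compound 1 gives 14%, and compound 2 gives 26%. Within the data shown here, compound 2 stands highest of the two numbers; its only neighbour, compound 1, lies lower by a gap beyond the usual scatter. Among the measured compounds shown here, the two differ in more than one place, so the pair yields no single-point step, and the values are read only as they stand.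

Compound 3, `O=C(O)[C@@H]1NC[C@@H](O)[C@@H](O)[C@H]1O`, has not been measured. Compared with compound 2: the two compounds have the same atoms and bonds and differ only in configuration as drawn: 4 of 4 stereo elements differ (all stereocentres are inverted: mirror images); a stereocentre at a saturated ring carbon is drawn S in compound 2 and R in compound 3; a stereocentre at a saturated ring carbon is drawn S in compound 2 and R in compound 3; a stereocentre at a saturated ring carbon is drawn S in compound 2 and R in compound 3; a stereocentre at a saturated ring carbon is drawn R in compound 2 and S in compound 3. The shared core, with all its hydroxyl groups and the acid, is kept; only the handedness changes.

For the measured compounds named here, no step among the measured compounds addresses inversion of configuration, and the two numbers give no calibration for it. The working expectation is that compound 3 falls below compound 2, with a step from compound 2 to compound 3 of a number 16 percentage points lower from compound 2 to compound 3 (beyond the scatter), expected rather than known. Compound 3 is estimated at 10%, with a wide range from 0% to 30%.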

Compound 3, a percentage reported as inhibition, at one concentration (the size of the read-out at that concentration, not a potency): 26%
For compound 3 the middle estimate is 16 percentage points below the measured one; low and high end bracket the measured number.
By their numbers in this assay, from the lowest: compound 1; then compounds 2 and 3 (each within the scatter of the next).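

Inverting all stereocentres of the shared core gives no change at the digits printed from compound 2 to compound 3 (within the scatter) in this assay, the first reading in this series of configuration on its own, since compounds 1 and 2 differ in more than one place. At this single concentration, the read-out therefore does not separate the two mirror images, and complete inversion of the hydroxyl groups and the acid together leaves no visible mark on the inhibition. The pair isolates handedness as the only variable, because the comparison involves no change of group: the fact that compounds 2 and 3 differ only in the configuration as drawn

Complete inversion may hide the effects of individual stereocentres, so it remains open whether inverting one ring carbon alone, giving a diastereomer rather than a mirror image, would move the number, and a one-concentration percentage cannot say whether the two compounds would also match in potency. Also open, from the compounds shown here alone, is how the read-out would respond at the acid position to a methyl ester or a primary amide in place of the carboxylic acid, changes that would test that group directly rather than its orientation.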